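The compounds below may be only part of what the source reports. "The series", "measured", "known", "first", "only" and "open" are said of these compounds alone.

Measured compounds in the series:

Compound 1 `Cc1ccccc1OCC1=NCCO1`: 20%
Compound 2 `Cc1cccc(OCC2=NCCO2)c1`: 20%
Compound 3 `O=[N+]([O-])c1ccccc1OCC1=NCCO1`: 25%

All three values come from a toxicity assay on the whole organism with Rattus norvegicus as the target, at a dose of 200 mg/kg by the oral route; on this read-out higher numbers stand for a stronger effect at the one dose given and lower numbers for a weaker effect. In this assay compound 1 gives 20% and compound 2 gives 20%; the two numbers agree at the digits given and lie within the scatter of each other. The difference between the core of compound 1 and the core of compound 2 is not broken down here; the two share the same atoms joined differently.

Compound 3 carries the change nitro in place of methyl on an aromatic carbon relative to compound 1. In this assay compound 3 gives 25%, so the step is a number 5 percentage points higher from compound 1 to compound 3 (within the scatter), a shift that stays inside the scatter and therefore cannot be called a change.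

Compound 4 `O=[N+]([O-])c1cccc(OCC2=NCCO2)c1` is not yet measured. It differs from compound 2 by nitro in place of methyl on an aromatic carbon. Among the measured compounds shown here, this is the same kind of change as the one from compound 1 to compound 3, but not the same: in compound 3 the nitro sits ortho to a group of 7 heavy atoms, in compound 4 it sits meta to a group of 7 heavy atoms.

The step from compound 2 to compound 4 is expected to be a number 5 percentage points higher from compound 2 to compound 4 (within the scatter), a small one, because the same kind of change gave a number 5 percentage points higher from compound 1 to compound 3 (within the scatter) and compound 2 starts from 20%. For the measured compounds named here, compound 4 is therefore estimated at 25%, with a range from 12% to 38% reflecting the scatter of single-dose readings and the single precedent on which the expectation rests.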

Compound 4, a percentage reported as activity, at one dose (the size of the read-out at that dose, not a potency): 30%
Estimate against measurement, compound 4: 5 percentage points below; low and high end bracket the measured number.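

Read in this assay, nitro in place of methyl on an aromatic carbon gives a number 10 percentage points higher from compound 2 to compound 4 (within the scatter), the second pair in the series to carry this exchange. Set beside the first pair, the change shows no measurable dependence on which of the two cores carries it: the same change on two cores in this assay, a number 5 percentage points higher (within the scatter) from compound 1 to compound 3 and a number 10 percentage points higher (within the scatter) from compound 2 to compound 4, 5 percentage points apart, within the scatter of two such steps. That agreement is only between two steps that each stay inside the scatter, so the series does not show that the change does anything to the read-out on either core, and two pairs at a single oral dose give no basis for predicting a larger step on a further core.

The compounds shown carry only methyl or nitro on the aromatic ring, so they leave open whether any group at that aromatic carbon can move the reading in this assay beyond the scatter, for example an amine, a carboxylic acid or a longer chain such as propyl. Also open, going by these compounds, is how far the reading depends on the part shared by all four compounds, since a change to that shared part, or a reading at another dose, lies outside this set.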